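The compounds below may be only part of what the source reports. "The series", "measured", "known", "first", "only" and "open" are said of these compounds alone.

Compound 1 `CCCCNc1nc(N)nc2c1CN(C(C)=O)CC2`: 0.5 uM
Compound 2 `CCCCNc1nc(N)nc2c1CCN(C(C)=O)C2`: 0.4 uM
Compound 3 `CCCCNc1nc(N)nc2c1CN(Cc1ccc(-c3ccccc3)cc1)CC2`: 0.5 uM

In an assay on HEK293 cells for agonist activity at Toll-like receptor 8 (Homo sapiens), read by a luciferase reporter, with a stated time of 6 h (on this read-out higher numbers stand for an effect only at larger amounts of compound and lower numbers for an effect already at smaller amounts), compound 1 gives 0.5 uM, compound 2 gives 0.4 uM and compound 3 gives 0.5 uM. The three values sit within the scatter of one another, so the data show no distinction among them; a large biphenylmethyl group on the ring nitrogen in compound 3 and an acetyl group in compound 1 come out the same. Compound 4 `CCCCNc1nc(N)nc2c1CN(C(=O)c1csnn1)CC2` is not yet measured; it differs from compound 1 in a single place: 1,2,3-thiadiazol-4-yl in place of methyl on a carbonyl carbon. Since compound 3 shows that a much larger group at this position leaves the value unchanged, the step of no change at the digits printed from compound 1 to compound 4 (within the scatter) is expected to be small, with no direction beyond the scatter. Compound 4 is therefore estimated at 0.5 uM, in the range 0.15 uM to 1.5 uM.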

Compound 4, minimum effective concentration: 0.1 uM
Compound 4: middle estimate off by 5.0-fold (0.70 log units), on the high side, and the stated range ends above it.
By their numbers in this assay, from the lowest: compound 4; then compounds 2, 1 and 3 (each within the scatter of the next).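

In this assay, replacing methyl with 1,2,3-thiadiazol-4-yl on the carbonyl carbon gives a 5.0-fold lower number from compound 1 to compound 4 (0.70 log units; beyond the scatter). The earlier compounds shown here sat within the scatter of one another, but this step shows that the group on this carbonyl carbon can move the number to lower values. No available data explain the step.

The compounds shown do not tell whether the ring as such or its nitrogen and sulfur atoms matter, which a phenyl or thiophene ring on the same carbonyl carbon could separate. From the compounds shown here alone, how an amine or a longer chain there would read also stays open.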